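Dechlorination on the fused aromatic ring: compound 2 to compound 4

The source may report more compounds than this note shows. Statements on the series, on what has been measured and on what is new or still open speak of the compounds shown alone.

The series is followed in a functional assay on the whole organism for antagonist activity, with Rattus norvegicus as the target; on this read-out higher numbers stand for an effect only at larger amounts of compound and lower numbers for an effect already at smaller amounts. Compound 1 `c1ccc2c(c1)CC2CN1CCN(c2cccc3c2OCCCO3)CC1` gives 0.63 mg/kg. Compound 2 `Clc1cccc2c1CC2CN1CCN(c2cccc3c2OCCO3)CC1` gives 0.63 mg/kg, level with compound 1 at the digits shown; the two stand together as the highest of the three numbers, and the gap between them lies within the scatter. Compound 3 `c1ccc2c(c1)CC(CCN1CCN(c3cccc4c3OCCO4)CC1)C2` gives 0.16 mg/kg, a lower number than compound 2, and this gap lies beyond the scatter.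

The step to compound 4 `c1ccc2c(c1)CC2CN1CCN(c2cccc3c2OCCO3)CC1` removes the halogen from the core of compound 2: hydrogen in place of chloro on an aromatic carbon. Going by the values given here, no pair among the measured compounds differs in this place alone, so no measured step shows what removing the chloro does here; compound 1 and compound 3 each differ from compound 4 elsewhere as well and give no direct guide.

Without a matching step, the change is expected to be small, with no direction that can be claimed beyond the scatter; the step of a 1.3-fold higher number from compound 2 to compound 4 (0.10 log units; within the scatter) is estimated as falling within the scatter, leaning slightly toward a higher number. Compound 4 is therefore expected to give about 0.8 mg/kg, within a range from 0.3 mg/kg to 2.5 mg/kg.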

Compound 4, minimum effective dose: 0.63 mg/kg
Beside the measured number, compound 4's estimate is 1.3-fold (0.10 log units) above it; measured number inside the range.
By their numbers in this assay, from the lowest: compound 3; then compounds 1, 2 and 4 (each within the scatter of the next).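

In this assay, going by these compounds alone, the step of no change at the digits printed from compound 2 to compound 4 (within the scatter) gives the first direct reading at this position, since no earlier pair differed in this place alone. On this aromatic carbon of the fused system of two rings, hydrogen in place of chloro leaves the read-out within the scatter, so in this pair the chloro is not needed for the effect to appear at this dose level, and the one heavy atom it adds makes no visible difference to the minimum effective dose. The data offer no explanation for this result, and what the chloro does or does not do beyond this read-out remains unaddressed.

The compounds shown leave open whether another group on this aromatic carbon, such as fluoro, methoxy, a nitrile or an amine, would give a different read-out from chloro and hydrogen. They also leave open whether the same exchange would read the same way on the core of compound 3, whose number lies beyond the scatter from that of compound 2.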